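Replacing the Acetyl on the Chain Carbon at the Ring Nitrogen

The compounds below may be only part of what the source reports. "The series", "measured", "known", "first", "only" and "open" are said of these compounds alone.

Measured so far:
Compound 1 `CCn1nc(-c2cccnc2)c2ccccc2c1=O` gives 87%.
Compound 2 `CC(C)=CCn1nc(-c2cccnc2)c2ccccc2c1=O` gives 94%.
Compound 3 `CC(=O)Cn1nc(-c2cccnc2)c2ccccc2c1=O` gives 13%.

All three numbers come from an assay on isolated protein (Oryctolagus cuniculus) with Thromboxane-A synthase (Homo sapiens) as the target, tested at 1 uM; on this read-out higher numbers stand for more inhibition at the one concentration tested (going by the name of the read-out) and lower numbers for less inhibition. Compound 3 stands lowest of the three: its nearest neighbour is compound 1, with a gap of a number 74 percentage points lower from compound 1 to compound 3 (beyond the scatter), and its furthest is compound 2, with a gap of a number 81 percentage points lower from compound 2 to compound 3 (beyond the scatter). Both are large steps, and both arise from the same kind of exchange, an acetyl taking the place of a methyl or of a 2-methylprop-1-en-1-yl on the saturated chain carbon bound to the aromatic nitrogen. By contrast the step of a number 7 percentage points higher from compound 1 to compound 2 (within the scatter) shows that swapping one of those two groups for the other leaves the read-out where it was.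

Compound 4 `COCCn1nc(-c2cccnc2)c2ccccc2c1=O` is not yet measured. It differs from compound 3 as follows: methoxymethyl in place of acetyl on a saturated chain carbon bound to an aromatic nitrogen. This change removes the acetyl that sets compound 3 apart from the other two, and nothing else in the molecule moves. For the measured compounds named here, the two large drops into compound 3 are the steps that bear on it; read in reverse, they suggest that taking the acetyl away should carry the number most of the way back up. Compound 4 is therefore expected to show a large rise, a number 62 percentage points higher from compound 3 to compound 4 (beyond the scatter), well beyond the scatter. The estimate for compound 4 in this assay is 75%, with a range from 45% to 95%.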

Compound 4, a percentage reported as inhibition, at one concentration (the size of the read-out at that concentration, not a potency): 55%
The estimate for compound 4 lay 20 percentage points above the measured number; measured number inside the range.
By their numbers in this assay, from the lowest: compound 3; then compound 4; then compounds 1 and 2 (each within the scatter of the next).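

Taking the acetyl away recovers only part of the loss: in this assay the exchange gives a number 42 percentage points higher from compound 3 to compound 4 (beyond the scatter), yet the methoxymethyl group does not reach the level of the two compounds without oxygen in this chain, as a number 32 percentage points lower from compound 1 to compound 4 (beyond the scatter) and a number 39 percentage points lower from compound 2 to compound 4 (beyond the scatter) show. Acetyl and methoxymethyl have the same counts of heavy atoms, carbon, oxygen and hydrogen-bond acceptors, so those counts do not separate compound 3 from compound 4, and across the four compounds shown, the two whose chain carries oxygen stand below the two whose chain does not, with no compound going against this. Nothing shown gives a cause for these differences.

On these data alone, it stays open whether a chain oxygen lowers the number wherever it stands, or whether a hydroxyl or a longer ether chain would behave like the methoxymethyl group. An amine or a carboxylic acid at the end of this chain would test whether the fall seen here extends to other groups carrying nitrogen or oxygen.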